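The compounds below may be only part of what the source reports. "The series", "measured", "known", "first", "only" and "open" are said of these compounds alone.

Compound 2 `COc1ccc(S(=O)(=O)N(Cc2cccc(Br)c2)[C@H](C)C(=O)NO)cc1` gives 93 nM in an assay on isolated protein for inhibition of bone morphogenetic protein 1 (Homo sapiens); a higher number here means a weaker inhibitor, a lower number a stronger inhibitor. Compound 1 `COc1ccc(S(=O)(=O)N(CCn2cccc2)[C@H](C)C(=O)NO)cc1` gives 170 nM in this assay. Compound 2 holds the lowest of the two numbers, yet the step of a 1.8-fold lower number from compound 1 to compound 2 (0.26 log units; within the scatter) lies within the scatter, so the two compounds cannot be told apart on these data. Compound 3 `COc1ccc(S(=O)(=O)N(Cc2ccc(SC)cc2)[C@H](C)C(=O)NO)cc1` differs from compound 2 in one place: 4-(methylsulfanyl)phenyl in place of 3-bromophenyl on a saturated chain carbon bound to a sulfonamide nitrogen is the change. For the measured compounds named here, no measured step covers this exchange; the only step recorded is a 1.8-fold lower number from compound 1 to compound 2 (0.26 log units; within the scatter) and it concerns a different group at the same place, showing that swapping the group there left the number inside the scatter. Compound 3 is therefore expected to stay near the number of compound 2. The step of a 1.2-fold higher number from compound 2 to compound 3 (0.07 log units; within the scatter) is expected to remain within the scatter. The estimate for compound 3 in this assay is 110 nM with a range from 40 nM to 300 nM.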

Compound 3, half-maximal inhibitory concentration: 80 nM
Compound 3: the middle estimate sits 1.4-fold (0.14 log units) above what was measured, within the range that was stated.
By their numbers in this assay, from the lowest: compounds 3, 2 and 1 (each within the scatter of the next, the first and the last beyond it).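

On a saturated chain carbon bound to a sulfonamide nitrogen, 4-(methylsulfanyl)phenyl in place of 3-bromophenyl gives a 1.2-fold lower number from compound 2 to compound 3 (0.07 log units; within the scatter) in this assay, so a phenyl group carrying bromine and one carrying sulfur cannot be told apart here. For the compounds shown here, the same place now also gives a first step beyond the scatter: 4-(methylsulfanyl)phenyl in place of (1H-pyrrol-1-yl)methyl gives a 2.1-fold lower number from compound 1 to compound 3 (0.33 log units; beyond the scatter), a modest difference that only just clears the scatter. No measurement shown here points to a cause for either step.

The two phenyl groups differ both in what they carry and in where they carry it, so these compounds cannot separate those two changes. Also open, from the compounds shown here alone, is how a phenyl group carrying an amine or a carboxylic acid would read in this assay.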